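A few compounds are considered here, and "the series" means these few. Any claim that something is new, unique, unknown or untested is made for them only; others in the source may bear on it.

Compound 2 `C=CCONC(=O)CN1C(=O)S/C(=C\c2ccc(C(F)(F)F)cc2)C1=O` is the starting point here, and it was tested in an ADME assay on RAW264.7 cells (Mus musculus) for cytotoxicity, read by neutral red uptake, with a stated time of 24 h; a lower number here means that less compound is tolerated, a higher number that more compound is tolerated. In this assay compound 2 gives > 128000 nM, which is a limit of the assay and not a number. Its relative compound 1 `O=C(CN1C(=O)S/C(=C\c2ccc(C(F)(F)F)cc2)C1=O)NOCc1ccccc1` gives > 128000 nM, which is also a limit. Compound 3 `C=CCONC(=O)C(C)N1C(=O)S/C(=C\c2ccc(C(F)(F)F)cc2)C1=O` gives > 128000 nM, again a limit. Together these results make up (the limit of > 128000 nM in this assay, at which 3 of the 3 values shown sit), so no true value is known for any of the three.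

Compound 4 `C=CCONC(=O)CN1C(=O)S/C(=C\c2ccc(F)cc2)C1=O` has not yet been measured. It differs from compound 2 in one place: fluoro in place of trifluoromethyl on an aromatic carbon, with fluoro in place of trifluoromethyl on an aromatic carbon.

Two measured steps lie close by, a step that the two limits leave unreadable from compound 1 to compound 2 and a step that the two limits leave unreadable from compound 2 to compound 3. Neither alters that aromatic carbon and neither has a readable size, so they offer only indirect guidance. Still, compound 1 and compound 3 both stay at the same limit as compound 2, so no step beyond the usual scatter is expected, and no direction can be given. The estimate therefore means a number no higher from compound 2 to compound 4 (the limit leaves the size open) as the expected step. For compound 4 the estimated value is 128000 nM, with an expected range from 50000 nM to 256000 nM and a strong chance that the assay again reports only a limit.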

Compound 4, half-maximal cytotoxic concentration: > 128000 nM
Compound 4: a limit, no number (the forecaster's own chance of this, stated with the estimate: 80%); the middle value lies on the limit itself.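

Compound 4 gives > 128000 nM, which is a limit of the assay and not a number. Compound 2 also stands at a limit, so no step can be read between compound 2 and compound 4: the limit of > 128000 nM in this assay, at which 4 of the 4 values shown sit. The compounds shown leave open the true tolerated concentration of each in this assay, and whether trifluoromethyl and fluoro differ there at all.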